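A few compounds are considered here, and "the series" means these few. Any claim that something is new, unique, unknown or untested is made for them only; others in the source may bear on it.

Going by the values given here, in an ADME assay on the whole organism (strain Sprague-Dawley) with Rattus norvegicus as the target, at a dose of 0.5 mg/kg by the intravenous route (a higher number here means that the compound lasts longer, a lower number that the compound disappears faster), compound 3 `CC(C)(C)C#Cc1cc(N(C(=O)[C@H]2CC[C@H](C)CC2)[C@H]2CC[C@H](Oc3ccc(=O)[nH]n3)CC2)c(C(=O)O)s1` gives 1.6 h, the middle of the three numbers so far. Compound 2 `CC(C)(C)C#Cc1cc(N(C(=O)[C@H]2CC[C@H](C)CC2)[C@H]2CC[C@H](OC3CCOC3)CC2)c(C(=O)O)s1` sits higher at 3.5 h, and compound 1 `CC(C)(C)C#Cc1cc(N(C(=O)[C@H]2CC[C@H](C)CC2)[C@H]2CC[C@@H](Oc3ccc(=O)[nH]n3)CC2)c(C(=O)O)s1` sits lower at 0.5 h.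

The next compound, compound 4 `CC(C)(C)C#Cc1cc(N(C(=O)[C@H]2CC[C@H](C)CC2)[C@H]2CC[C@H](Oc3ccncn3)CC2)c(C(=O)O)s1`, keeps the shared core and changes only what sits on an oxygen on a saturated carbon: a group of 6 heavy atoms (4 carbon, 2 nitrogen; one six-membered aromatic ring with 2 hetero atoms) in place of a group of 7 heavy atoms (4 carbon, 2 nitrogen, 1 oxygen; one six-membered aromatic ring with 2 hetero atoms), on an oxygen on a saturated carbon. The closest guide is the swap at that same place, a 2.2-fold lower number from compound 2 to compound 3 (0.34 log units; beyond the scatter). It shows that the group there can move the number beyond the scatter, although a different group is involved. The other measured step, a 3.2-fold higher number from compound 1 to compound 3 (0.51 log units; beyond the scatter), rests on (the fact that compounds 1 and 3 differ only in the configuration as drawn), so it says little about exchanging one group for another.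

Among the compounds with values here, with only one relevant step, and that one modest, a small rise is expected rather than a large change. The estimated step is a 1.4-fold higher number from compound 3 to compound 4 (0.14 log units; within the scatter). In this assay, compound 4 is therefore expected at 2.2 h, with a likely range from 1 h to 4.5 h.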

Compound 4, mean residence time: 7.1 h
For compound 4 the middle estimate is 3.2-fold (0.51 log units) below the measured one; measured number outside the range, above it.
By their numbers in this assay, from the lowest: compound 1; then compound 3; then compound 2; then compound 4.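

In this assay, the exchange at the oxygen on a saturated carbon gives a 4.4-fold higher number from compound 3 to compound 4 (0.65 log units; beyond the scatter), so this position responds strongly even when one six-membered aromatic ring with 2 hetero atoms replaces another; that ring type alone does not set the number. Pyrimidin-4-yl in place of oxolan-3-yl gives a 2.0-fold higher number from compound 2 to compound 4 (0.31 log units; beyond the scatter), whereas compound 3 sits below compound 2, so an aromatic ring at this place can go with either a higher or a lower number than oxolan-3-yl. Nothing available here explains why the number rises with pyrimidin-4-yl.

The group that leaves differs from pyrimidin-4-yl in both its hydrogen-bond donor and its double bond outside the ring, and these compounds cannot separate the two. Going by these compounds, how a phenyl ring or a pyridine ring would behave at this oxygen remains open.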